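Changing one sulfonamide group to reach compound 3

The source may hold more compounds than are shown below. What is called first, only, known or untested is meant among the compounds shown, and "the series" means these compounds.

- compound 1 `O=C(/C=C/c1cccnc1)NCCCCCCCc1cccc(S(=O)(=O)Nc2ccccc2)c1` gives 138 nM
- compound 2 `Cc1cccc(NS(=O)(=O)c2cccc(CCCCCCNC(=O)/C=C/c3cccnc3)c2)c1` gives 13.2 nM

Both values come from a functional assay on Huh-7 cells (Homo sapiens) for inhibition, read by CCK-8 assay, with a stated time of 72 h (on this read-out lower numbers stand for stronger inhibition and higher numbers for weaker inhibition), and can be compared directly. Compound 2 has the lower of the two numbers (13.2 nM), and its gap to compound 1 lies beyond the usual scatter. These two compounds do not differ in just one place, so the data do not isolate the effect of any single change.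

Compound 3 `O=C(/C=C/c1cccnc1)NCCCCCCc1cccc(S(=O)(=O)Nc2ccc(F)cc2)c1` matches compound 2 except for one group (4-fluorophenyl in place of 3-methylphenyl on a sulfonamide nitrogen). On a sulfonamide nitrogen, 4-fluorophenyl takes the place of 3-methylphenyl. Each group has one six-membered aromatic ring of carbon only and no net charge.

Within the data shown here, no measured pair shows what this swap does, so any forecast in this assay is uncertain. The low number of compound 2 (13.2 nM) makes a slightly higher number seem more likely than a lower one, but no shift beyond the scatter is expected. The expected change is a 1.5-fold higher number from compound 2 to compound 3 (0.18 log units; within the scatter) and would stay within the usual scatter. The estimated value for compound 3 is 20 nM (expected range 6 nM to 70 nM).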

Compound 3, half-maximal inhibitory concentration: 4.28 nM
Estimate against measurement, compound 3: 4.7-fold (0.67 log units) above, and the stated range ends above it.
By their numbers in this assay, from the lowest: compound 3; then compound 2; then compound 1.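

In this assay, the group on the sulfonamide nitrogen makes a clear difference: 4-fluorophenyl in place of 3-methylphenyl gives a 3.1-fold lower number from compound 2 to compound 3 (0.49 log units; beyond the scatter). This is the first pair shown that differs in one place only, so the shift can be tied to this single change, which the gap between compound 1 and compound 2 could not do. The two groups match in heavy-atom count and each has one aromatic ring of carbon only, yet the number still moves beyond the usual scatter, so this position responds even to a swap this small, and no measured evidence here accounts for the shift.

Still open, as far as these compounds go, is how this position responds to other groups, such as 4-chlorophenyl, 4-methoxyphenyl, or a phenyl ring carrying an amine or a carboxylic acid. Compounds bearing 3-fluorophenyl and 4-methylphenyl on the same nitrogen would show whether the step follows from the change of methyl to fluorine or from the different placement of that group on the ring.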